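Swapping a nitro-bearing ring for an amino-bearing one

The source may report more compounds than this note shows. Statements on the series, on what has been measured and on what is new or still open speak of the compounds shown alone.

Measured compounds in a functional assay on HCT-116 cells (Homo sapiens) for cytotoxicity, read by MTT assay, with a stated time of 72 h; on this read-out higher numbers stand for weaker inhibition and lower numbers for stronger inhibition:
- compound 1 `CCOC(=O)C1=C(C)NC(=O)NC1c1cn(C(=O)CNc2ccccc2[N+](=O)[O-])c2ccccc12` gives 250 ug/mL
- compound 2 `CCOC(=O)C1=C(C)NC(=O)NC1c1cn(C(=O)CNc2ccc([N+](=O)[O-])cc2)c2ccccc12` gives "not determined" (no result reported); no result was reported for it

Compound 1 and compound 2 share one core and differ only in where the nitro group sits on the outer ring. Compound 1 shows weak inhibition in this assay, and for compound 2 no number exists, so compound 2 stands nowhere on the scale yet. Compound 3 `CCOC(=O)C1=C(C)NC(=O)NC1c1cn(C(=O)CNc2ccccc2N)c2ccccc12` is built from compound 2 by the change (2-aminophenyl in place of 4-nitrophenyl on an amine nitrogen). For the measured compounds named here, with no measured pair that differs in one place, no step size can be read from the data, so only the value of compound 1 guides an expectation: a weak result of similar order, without a stated direction beyond the scatter. Compound 3 is therefore expected to give about 200 ug/mL in this assay, within a range from 50 ug/mL to 600 ug/mL.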

Compound 3, half-maximal inhibitory concentration: 300 ug/mL
Compound 3: middle estimate off by 1.5-fold (0.18 log units), on the low side; the range from low to high includes it.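

For the compounds shown here, the one pair that can be compared is compound 1 and compound 3, which differ only in having amino in place of nitro on an aromatic carbon. In this assay this gives a 1.2-fold higher number from compound 1 to compound 3 (0.08 log units; within the scatter) and so the two values cannot be told apart, which means this exchange on the outer ring does not separate the compounds in this cytotoxicity test. Nothing shown explains this result.

Steps involving compound 2 cannot be read, so the placing of the nitro group on the outer ring remains an open question. Also open, from the compounds shown here alone, is how a carboxylic acid or a methoxy group on that ring would compare in this assay and what a longer chain joining the ring to the shared core would do.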